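Dropping the chloro from the cinnamoyl ring of compound 2

The compounds below may be only part of what the source reports. "The series", "measured", "known", "first", "only" and "open" are said of these compounds alone.

Compound 1, `Cc1nc(Nc2cccc(Cl)c2)sc1C(=O)/C=C/c1ccccc1`, gives in a functional assay on PC-3 cells (Homo sapiens) for cytotoxicity, read by MTT assay (a lower number here means a stronger inhibitor, a higher number a weaker inhibitor), only the assay limit > 25000 nM.
Compound 2, `Cc1nc(Nc2ccc(Cl)cc2)sc1C(=O)/C=C/c1ccc(Cl)cc1`, gives in this assay only the assay limit > 25000 nM.

Among the compounds with values here, compound 2 thus stands at a limit, not at a number, and the same holds for the one other value shown, as the limit of > 25000 nM in this assay, at which 2 of the 2 values shown sit, records. Within the data shown here, no step between measured compounds exists to lean on. Compound 3, `Cc1nc(Nc2ccc(Cl)cc2)sc1C(=O)/C=C/c1ccccc1`, differs from compound 2 by hydrogen in place of chloro on an aromatic carbon. With both measured values at the limit, no change in this assay beyond the scatter is expected, so the step that the limit leaves unreadable from compound 2 to compound 3 is an estimate of no real movement. Compound 3 is expected at 40000 nM, within 15000 nM to 120000 nM, most likely again reported as a limit.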

Compound 3, half-maximal inhibitory concentration: 24600 nM
Estimate against measurement, compound 3: 1.6-fold (0.21 log units) above; the measured number falls inside the stated range.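

In this assay, within the data shown here, compound 3 gives 24600 nM, the first value that is a number and not a limit. Hydrogen in place of chloro gives an at least 1.0-fold lower number from compound 2 to compound 3 (0.00 log units; that floor lies within the scatter), and 4-chlorophenyl in place of 3-chlorophenyl on the nitrogen gives an at least 1.0-fold lower number from compound 1 to compound 3 (0.00 log units; that floor lies within the scatter). Neither step shows a change beyond the scatter, and their true size stays unknown because compound 1 and compound 2 both stand at a limit: the limit of > 25000 nM in this assay, at which 2 of the 3 values shown sit.

Open, as far as these compounds go, is whether a methoxy group or an amine on that phenyl moves the number clearly away from the limit. Also open, from the compounds shown here alone, is how a carboxylic acid at the same place would read.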